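A few compounds are considered here, and "the series" means these few. Any claim that something is new, unique, unknown or untested is made for them only; others in the source may bear on it.

Measured compounds:
Compound 1 `COc1cc(/C=C/C(=O)c2cccc(-n3cc(-c4ccccc4)[nH]c3=O)c2)cc(OC)c1OC` gives 1370 nM.
Compound 2 `COc1cc(/C=C/C(=O)c2cccc(-n3cc(-c4ccccc4)[nH]c3=O)c2)ccc1O` gives 1610 nM.
Compound 3 `O=C(/C=C/c1cccc(O)c1)c1cccc(-n2cc(-c3ccccc3)[nH]c2=O)c1` gives 1830 nM.

These three compounds were tested in a functional assay on KM12 cells (Homo sapiens) for inhibition; a higher number here means a weaker inhibitor of growth, a lower number a stronger inhibitor of growth. Compound 1 stands within the usual scatter of both compound 2 and compound 3, so the three cannot be told apart on these numbers. Among the measured compounds shown here, the one measured step, a 1.1-fold higher number from compound 2 to compound 3 (0.06 log units; within the scatter), changes the aryl group on the double-bonded chain carbon, and it stays within the scatter.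

Compound 4 `COc1cc(/C=C/C(=O)c2cccc(-n3cc(-c4cc(OC)c(OC)c(OC)c4)[nH]c3=O)c2)cc(OC)c1OC` has not yet been measured. It differs from compound 1 by 3,4,5-trimethoxyphenyl in place of phenyl on an aromatic carbon. For the measured compounds named here, no measured step touches this position: the only step known concerns the other aryl group of the shared core, and it was within the scatter. There is therefore nothing in the data to support a step in either direction, and the expectation rests on compound 1 alone, with wide uncertainty.

Compound 4 is expected to give about 1400 nM in this assay, within 350 nM to 5600 nM, which would mean a 1.0-fold higher number from compound 1 to compound 4 (0.01 log units; within the scatter).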

Compound 4, concentration for 50% growth inhibition: 1120 nM
For compound 4 the middle estimate is 1.3-fold (0.10 log units) above the measured one; the measured number falls inside the stated range.
By their numbers in this assay, from the lowest: compounds 4, 1, 2 and 3 (each within the scatter of the next).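

This position on an aromatic carbon of a five-membered aromatic ring with 2 nitrogen held phenyl in compound 1, compound 2 and compound 3, so the replacement by 3,4,5-trimethoxyphenyl gives its first reading in this assay: a 1.2-fold lower number from compound 1 to compound 4 (0.09 log units; within the scatter) is the whole effect seen. A group of 12 heavy atoms and 3 hydrogen-bond acceptors thus stands where phenyl stood, with no change in growth inhibition that can be told from the scatter. No other measurement bears on this result.

The compounds shown leave open whether an amine, a carboxylic acid or a longer chain on this aromatic carbon would move the number beyond the scatter. They also leave open how 3,4,5-trimethoxyphenyl here would read alongside the aryl groups of compound 2 and compound 3.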